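Cytotoxicity Limits in a Shared Core, and a Third Compound

This account rests on a few compounds, and the source may have more. Where it says the series, first, only, none or still open, it means among the compounds named here.

The study reports an ADME assay on MT4 cells (Homo sapiens) for cytotoxicity, read by MTT assay (on this read-out higher numbers stand for lower toxicity in this test and lower numbers for higher toxicity in this test), for two compounds built on one shared core. Compound 1 `O=C(CSc1nnnn1-c1cccc2ccccc12)N/N=C/c1cccs1` carries thiophen-2-yl on a carbon with a double bond to nitrogen. In this assay compound 1 gives only a limit of the assay, > 316000 nM. Compound 2 `COc1cc(/C=N/NC(=O)CSc2nnnn2-c2cccc3ccccc23)ccc1O` carries 4-hydroxy-3-methoxyphenyl at that place. In this assay compound 2 likewise gives only a limit, > 287000 nM. The step that the two limits leave unreadable from compound 1 to compound 2 therefore cannot be sized. Compound 1 sits at the limit of > 316000 nM in this assay, at which 1 of the 2 values shown sits. Within the data shown here, compound 2 sits at the limit of > 287000 nM in this assay, at which 1 of the 2 values shown sits, so compound 2 stands at a limit rather than a number, and no measured compound offers a number to compare it with.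

Compound 3 `O=C(CSc1nnnn1-c1cccc2ccccc12)N/N=C/c1ccccc1O` has not yet been measured and differs from compound 2 by 2-hydroxyphenyl in place of 4-hydroxy-3-methoxyphenyl on a carbon with a double bond to nitrogen. Among the measured compounds shown here, the only measured step at this place, a step that the two limits leave unreadable from compound 1 to compound 2, is unreadable, so no direction can be drawn from it. Compound 3 is expected to show a step that the limit leaves unreadable from compound 2 to compound 3, none beyond the scatter. Compound 3 is thus estimated at 300000 nM, in a range from 120000 nM to 700000 nM, most likely again reported as a limit.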

Compound 3, half-maximal cytotoxic concentration: 4850 nM
Compound 3: the middle estimate sits 62-fold (1.79 log units) above what was measured; the measured number lies below the stated range.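

This place on the shared core, a carbon with a double bond to nitrogen, turns out to matter in this assay: 2-hydroxyphenyl brings an at least 59-fold lower number from compound 2 to compound 3 (1.77 log units; beyond the scatter), and set against thiophen-2-yl it brings an at least 65-fold lower number from compound 1 to compound 3 (1.81 log units; beyond the scatter). Among these compounds, compound 3 is the first here to give a number instead of a limit, showing that a change at this place alone can reach the lower side of the read-out, which stands for higher toxicity in this test, although the step from thiophen-2-yl starts from a limit: the limit of > 316000 nM in this assay, at which 1 of the 3 values shown sits. The step from 4-hydroxy-3-methoxyphenyl also starts from a limit, so both sizes are minimum sizes, and the step between the two limits themselves remains unreadable: the limit of > 287000 nM in this assay, at which 1 of the 3 values shown sits.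

The compounds shown leave open whether the drop belongs to the hydroxy group of 2-hydroxyphenyl or to the ring as a whole, a question that plain phenyl or 2-methoxyphenyl at this place would help to settle. They also leave open how far the change extends to other groups on this ring, such as an amine or a carboxylic acid.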